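Swapping the Alkenyl Arm for a Branched Phenyl Group

The source may hold more compounds than are shown below. What is called first, only, known or untested is meant among the compounds shown, and "the series" means these compounds.

Compound 1 `CC(C)=CCn1ccc2cc(/C(C)=C/C(=O)Nc3ccccc3OCCCC(=O)O)ccc21` gives 120 nM in an assay on Prostate gland for inhibition of steroid 5-alpha-reductase (Rattus norvegicus); on this read-out higher numbers stand for weaker inhibition and lower numbers for stronger inhibition. Compound 2 `CCCCc1ccc(Cn2ccc3cc(/C(C)=C/C(=O)Nc4ccccc4OCCCC(=O)O)ccc32)cc1` gives 100 nM in this assay.

Among the measured compounds shown here, compound 1 has the highest of the two numbers, but its only neighbour is close: a 1.2-fold lower number from compound 1 to compound 2 (0.08 log units; within the scatter). Compound 3 `C/C(=C\C(=O)Nc1ccccc1OCCCC(=O)O)c1ccc2c(ccn2C(c2ccccc2)C(C)C)c1` changes the same place, (2-methyl-1-phenylpropyl in place of 3-methylbut-2-en-1-yl on an aromatic nitrogen). For the measured compounds named here, the one measured step on this position bears on it, and since the move to compound 2 stayed within the scatter, a group carrying a phenyl ring appears tolerated here. Compound 3 is therefore expected to stay near compound 1, with a 1.1-fold lower number from compound 1 to compound 3 (0.04 log units; within the scatter). The estimate for compound 3 in this assay is 110 nM, ranging from 40 nM to 330 nM.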

Compound 3, half-maximal inhibitory concentration: 25 nM
Compound 3: middle estimate off by 4.4-fold (0.64 log units), on the high side; the measured number lies below the stated range.
By their numbers in this assay, from the lowest: compound 3; then compounds 2 and 1 (each within the scatter of the next).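

In this assay, this position on the aromatic nitrogen proves able to shift the number: 2-methyl-1-phenylpropyl gives a 4.8-fold lower number from compound 1 to compound 3 (0.68 log units; beyond the scatter) and also a 4.0-fold lower number from compound 2 to compound 3 (0.60 log units; beyond the scatter), while the 4-butylbenzyl of compound 2 stayed within the scatter of compound 1. Carrying a phenyl ring is therefore not enough on its own, since only compound 3 stands apart among these three. No available evidence explains the difference between these groups. Still open, from the compounds shown here alone, is whether a plain benzyl group would reach the level of compound 3, and whether an amine or a carboxylic acid on this arm would be accepted.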